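Swapping the Thiophene for a Styryl Group

The source may hold more compounds than are shown below. What is called first, only, known or untested is meant among the compounds shown, and "the series" means these compounds.

Compound 1, `COc1ccccc1C1C(C#N)=C(N)N(c2cc(OC)c(OC)c(OC)c2)C2=C1C(=O)CC(C)(C)C2`: 30%
Compound 2, `COc1cc(N2C(N)=C(C#N)C(c3cccs3)C3=C2CC(C)(C)CC3=O)cc(OC)c1OC`: 5%
Compound 3, `COc1cc(N2C(N)=C(C#N)C(c3c(OC)ccc4ccccc34)C3=C2CC(C)(C)CC3=O)cc(OC)c1OC`: 0%

The three compounds share one core and differ only in the group on a saturated ring carbon. Among the measured compounds shown here, in a functional assay on Ehrlich cells (Mus musculus) for cytotoxicity, tested at 10 ug/mL (a higher number here means a stronger effect of the compound at the concentration tested, a lower number a weaker effect), compound 2 stands second highest of the three: its nearest neighbour is compound 3, with a number 5 percentage points lower from compound 2 to compound 3 (within the scatter), a gap inside the scatter, while the only compound clearly apart is compound 1, with a number 25 percentage points lower from compound 1 to compound 2 (beyond the scatter).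

Compound 4, `COc1cc(N2C(N)=C(C#N)C(/C=C/c3ccccc3)C3=C2CC(C)(C)CC3=O)cc(OC)c1OC`, is the next step from compound 2: 2-phenylethenyl in place of thiophen-2-yl on a saturated ring carbon. For the measured compounds named here, no measured step involves a 2-phenylethenyl group. The two steps that change this same position from 2-methoxyphenyl, a number 25 percentage points lower from compound 1 to compound 2 (beyond the scatter) and a number 30 percentage points lower from compound 1 to compound 3 (beyond the scatter), both lowered the read-out, and the exchange between thiophen-2-yl and 2-methoxynaphthalen-1-yl, a number 5 percentage points lower from compound 2 to compound 3 (within the scatter), stayed within the scatter. Compound 2 already sits near the floor of the scale, so little room for a further fall remains. The step to compound 4 is therefore expected to be a number 5 percentage points higher from compound 2 to compound 4 (within the scatter), not beyond the scatter. Compound 4 is estimated at 10%, in the range 0% to 30%.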

Compound 4, a percentage reported as activity, at one concentration (the size of the read-out at that concentration, not a potency): 10%
For compound 4 middle estimate and measured number coincide at the digits printed; measured number inside the range.
By their numbers in this assay, from the lowest: compounds 3, 2 and 4 (each within the scatter of the next); then compound 1.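

With 2-phenylethenyl, a double bond outside aromatic rings enters this saturated ring carbon's substituent, yet in this assay the change stays within the scatter on both sides, with a number 5 percentage points higher from compound 2 to compound 4 (within the scatter) and a number 10 percentage points higher from compound 3 to compound 4 (within the scatter). The separation from the 2-methoxyphenyl group holds, with a number 20 percentage points lower from compound 1 to compound 4 (beyond the scatter), so among the four groups shown, only that of compound 1 stands clear of the others. Nothing measured here accounts for this separation.

The compounds shown leave open whether a propyl chain or a ring bearing an amine on this same carbon would reach the read-out of compound 1 at 30%. They also leave open how a plain phenyl group at this carbon would compare with 2-methoxyphenyl.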